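Lengthening the ester chain on a ring amine

The source may hold more compounds than are shown below. What is called first, only, known or untested is meant among the compounds shown, and "the series" means these compounds.

Three compounds sharing one core were examined in a functional assay (strain AB) with Danio rerio as the target, read by microscopy, with a stated time of 1 h; on this read-out higher numbers stand for an effect only at larger amounts of compound and lower numbers for an effect already at smaller amounts. Compound 1 `CCN1CCc2c(sc(NC(=O)Nc3ccc4ccccc4c3)c2C(N)=O)C1` gives 1780 nM in this assay. Compound 3 `CC1(C)Cc2c(sc(NC(=O)Nc3ccc(Cl)cc3)c2C(N)=O)C(C)(C)N1` gives 1240 nM in this assay; these two numbers lie within the scatter of each other. Compound 2 `CC(C)(C)OC(=O)CN1CCc2c(sc(NC(=O)Nc3ccc(Cl)cc3)c2C(N)=O)C1` is different: it reaches only a limit of this assay, > 25000 nM. Compound 2 thus stands at the top of the numbers shown, a position described by the limit of > 25000 nM in this assay, at which 1 of the 3 values shown sits.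

Compound 4 `CC(C)(C)OC(=O)CCN1CCc2c(sc(NC(=O)Nc3ccc(Cl)cc3)c2C(N)=O)C1` has not yet been measured. It differs from compound 2 in a single place: (tert-butoxycarbonyl)methyl in place of tert-butoxycarbonyl on a saturated chain carbon bound to an amine nitrogen in a ring. Among the compounds with values here, no two measured compounds differ in only one place, so no measured step size is available to guide the expectation. In this assay the expected step is a number no higher from compound 2 to compound 4 (the limit leaves the size open), no larger than the scatter. Compound 4 is therefore estimated at 25000 nM, with a range from 8000 nM to 60000 nM, and with a considerable chance that this assay again reports only a limit for it.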

Compound 4, half-maximal effective concentration: 1100 nM
Compound 4: middle estimate off by 23-fold (1.36 log units), on the high side; the whole stated range lies above it.
By their numbers in this assay, from the lowest: compounds 4, 3 and 1 (each within the scatter of the next). At a limit, above all of these: compound 2.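

The position on a saturated chain carbon bound to an amine nitrogen in a ring turns out to respond strongly to a small change: (tert-butoxycarbonyl)methyl in place of tert-butoxycarbonyl gives an at least 22-fold lower number from compound 2 to compound 4 (1.35 log units; beyond the scatter) in this assay. Compound 4 still carries the tert-butyl ester, so this ester does not by itself hold the read-out at the limit of the assay. Compound 2 gives only a limit, which leaves the step with a bound and no exact size: the limit of > 25000 nM in this assay, at which 1 of the 4 values shown sits.

Going by these compounds, whether a longer chain carrying the same ester would lower the number further remains open, as does the effect of a carboxylic acid or an amine at the end of the chain. The compounds shown also give no reason for the step.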